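Methoxy removal in two hydrazone series, spectrophotometric inhibition

The source may hold more compounds than are shown below. What is called first, only, known or untested is meant among the compounds shown, and "the series" means these compounds.

Measured so far:
compound 1, `COc1cc(/C=N/NC(=O)OCc2ccccc2)cc(OC)c1O`, 60500 nM
compound 2, `COc1cc(/C=N/N2C(=O)CSC2=S)cc(OC)c1O`, 11800 nM
compound 3, `COc1cc(/C=N/NC(=O)OCc2ccccc2)ccc1O`, 39700 nM

All three values come from a physicochemical assay, read by spectrophotometry; on this read-out lower numbers stand for stronger inhibition and higher numbers for weaker inhibition. Compound 2 gives the lowest of the three numbers; compound 3 is nearest to it, compound 1 furthest, and both gaps lie beyond the scatter. How the core of compound 1 differs from the core of compound 2 is not broken down here.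

Compound 1 and compound 3 differ in one place, (hydrogen in place of methoxy on an aromatic carbon). The step this made is a 1.5-fold lower number from compound 1 to compound 3 (0.18 log units; within the scatter), a change that stays within the scatter.

Compound 4, `COc1cc(/C=N/N2C(=O)CSC2=S)ccc1O`, is not yet measured. It differs from compound 2 by hydrogen in place of methoxy on an aromatic carbon. The place lines of the two changes are not the same word for word: in compound 1 the position is meta to a large group, in compound 2 it is meta to a group of 9 heavy atoms, so the two are the same kind of change rather than the same change.

In this assay the step from compound 2 to compound 4 is expected to be small, a 1.5-fold lower number from compound 2 to compound 4 (0.17 log units; within the scatter), because the matching step a 1.5-fold lower number from compound 1 to compound 3 (0.18 log units; within the scatter) stayed within the scatter. On that basis compound 4 is estimated at 8000 nM, with a range from 4000 nM to 16000 nM. The estimate rests on a single earlier step in a different core, so it remains loose.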

Compound 4, half-maximal inhibitory concentration: 12900 nM
For compound 4 the middle estimate is 1.6-fold (0.21 log units) below the measured one; measured number inside the range.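

In this assay, replacing methoxy with hydrogen on the aromatic carbon gives a 1.1-fold higher number from compound 2 to compound 4 (0.04 log units; within the scatter), and the same kind of change in the core of compound 1 gave a 1.5-fold lower number from compound 1 to compound 3 (0.18 log units; within the scatter). Across these two pairs, the change therefore carries from one core to the other in a limited sense: one of the two methoxy groups can give way to hydrogen with neither step leaving the scatter, and the two steps should not be read as differing in direction or size. This does not establish a rule beyond these two pairs, nor does it show that the same would hold in any further core, and nothing available here bears on why the steps stay this small.

Still open, as far as these compounds go, is whether a different group at this position, such as an amine, a carboxylic acid or a longer chain such as ethoxy, would move the number beyond the scatter where hydrogen does not. The compounds shown also leave open what happens in either core when the remaining methoxy group or the hydroxy group is replaced.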